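Chromone side-chain amines: piperidine versus methylpiperazine

This account rests on a few compounds, and the source may have more. Where it says the series, first, only, none or still open, it means among the compounds named here.

Measured so far in a functional assay on HepG2 cells (Homo sapiens) for antiproliferative activity, read by MTT assay, with a stated time of 48 h; a higher number here means a weaker inhibitor, a lower number a stronger inhibitor:
compound 1 `COc1c(OCCCN2CCCCC2)cc2oc(-c3ccccc3)cc(=O)c2c1O` gives 6800 nM
compound 2 `COc1c(OCCCN2CCN(C)CC2)cc2oc(-c3ccccc3)cc(=O)c2c1O` gives 30400 nM
compound 3 `COc1c(OCCCCN2CCCCC2)cc2oc(-c3ccccc3)cc(=O)c2c1O` gives 2400 nM

Compound 3 carries the lowest of the three numbers. Its core differs from that of compound 1 by (piperidin-1-yl)methyl in place of piperidin-1-yl on a saturated chain carbon, three bonds along the chain from an oxygen on an aromatic ring, a change that reads a 2.8-fold lower number from compound 1 to compound 3 (0.45 log units; beyond the scatter). Against compound 2 the gap is larger, a 13-fold lower number from compound 2 to compound 3 (1.10 log units; beyond the scatter).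

The change of interest is 4-methylpiperazin-1-yl in place of piperidin-1-yl on a saturated chain carbon, three bonds along the chain from an oxygen on an aromatic ring, which made the step of a 4.5-fold higher number from compound 1 to compound 2 (0.65 log units; beyond the scatter). Compound 4 `COc1c(OCCCCN2CCN(C)CC2)cc2oc(-c3ccccc3)cc(=O)c2c1O` is not yet measured; it differs from compound 3 by 4-methylpiperazin-1-yl in place of piperidin-1-yl on a saturated chain carbon, four bonds along the chain from an oxygen on an aromatic ring. Among the compounds with values here, this is the same kind of change as the one from compound 1 to compound 2, though the place is not identical: in the earlier pair the amine sits three bonds along the chain from an oxygen on an aromatic ring, in the new pair four bonds along. Within the data shown here, only one measured instance of the change exists, so the expectation rests on it alone.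

The step from compound 3 to compound 4 is expected to be a 4.2-fold higher number from compound 3 to compound 4 (0.62 log units; beyond the scatter), chiefly because the earlier pair showed a 4.5-fold higher number from compound 1 to compound 2 (0.65 log units; beyond the scatter). Compound 4 is therefore expected to give about 10000 nM, within roughly 4000 nM to 26000 nM.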

Compound 4, half-maximal inhibitory concentration: 27200 nM
Compound 4: the middle estimate sits 2.7-fold (0.43 log units) below what was measured; measured number outside the range, above it.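

In this assay, 4-methylpiperazin-1-yl in place of piperidin-1-yl again goes with a higher number on the core with the longer chain (an 11-fold higher number from compound 3 to compound 4 (1.05 log units; beyond the scatter)); the longer chain together with that change also gives a higher number (a 4.0-fold higher number from compound 1 to compound 4 (0.60 log units; beyond the scatter)), while the longer chain alone, with 4-methylpiperazin-1-yl kept, makes no difference that stands out of the scatter (a 1.1-fold lower number from compound 2 to compound 4 (0.05 log units; within the scatter)). Within the data shown here, only two pairs support the transfer, and their cores differ only in chain length, so they show nothing about cores that differ in any other way and give no reason for the higher number. The change carried over in direction, and its size cannot be told apart on these two cores: the same change on two cores in this assay, a 4.5-fold higher number (0.65 log units; beyond the scatter) from compound 1 to compound 2 and an 11-fold higher number (1.05 log units; beyond the scatter) from compound 3 to compound 4, 2.5-fold (0.40 log units) apart, within the scatter of two such steps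

Still open, from the compounds shown here alone, is whether another amine at the chain end, such as morpholine or pyrrolidine, falls with piperidin-1-yl or with 4-methylpiperazin-1-yl. Going by these compounds, a longer chain also remains open, on either amine.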